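Aryl amide change on a quinoline series: compound 4 expected

This account rests on a few compounds, and the source may have more. Where it says the series, first, only, none or still open, it means among the compounds named here.

Compound 1 `CCN1CCN(c2cc(C)c3cc(NC(=O)c4ccc(Cl)cc4)ccc3n2)CC1` gives 3020 nM in a functional assay on SK-BR-3 cells (Homo sapiens) for antiproliferative activity, read by MTT assay, with a stated time of 72 h; a lower number here means a stronger inhibitor, a higher number a weaker inhibitor.
Compound 2 `Cc1cc(N2CCN(C(C)C)CC2)nc2ccc(NC(=O)c3ccc(Cl)c(Cl)c3)cc12` gives 6680 nM in this assay.
Compound 3 `Cc1cc(N2CCCCC2)nc2ccc(NC(=O)c3ccc(Cl)c(Cl)c3)cc12` gives 42500 nM in this assay.

Among the three measured compounds, compound 1 stands at the lowest number, and its nearest neighbour is compound 2, itself beyond the scatter; compound 3 lies furthest from it. For the measured compounds named here, the only step that changes one place at a time, a 6.4-fold higher number from compound 2 to compound 3 (0.80 log units; beyond the scatter), concerns the basic amine on the core and not the aryl amide, so it does not speak to the change examined here.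

Compound 4 `CCN1CCN(c2cc(C)c3cc(NC(=O)c4ccc(F)c(F)c4)ccc3n2)CC1` differs from compound 1 by 3,4-difluorophenyl in place of 4-chlorophenyl on a carbonyl carbon. Going by the values given here, no measured pair isolates this part of the molecule; compounds 1 and 2 differ in two places at once, so their values alone cannot be assigned to the amide. Without a bearing step, the expectation for compound 4 is a small step of uncertain direction, a 1.5-fold higher number from compound 1 to compound 4 (0.17 log units; within the scatter), and compound 4 is therefore estimated at 4500 nM, within a range from 1500 nM to 15000 nM.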

Compound 4, half-maximal inhibitory concentration: 1980 nM
For compound 4 the middle estimate is 2.3-fold (0.36 log units) above the measured one; measured number inside the range.
By their numbers in this assay, from the lowest: compounds 4 and 1 (each within the scatter of the next); then compound 2; then compound 3.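

For the compounds shown here, with the rest of the molecule held fixed, 3,4-difluorophenyl in place of 4-chlorophenyl on a carbonyl carbon gives the first reading of this part of the molecule alone in this assay (a 1.5-fold lower number from compound 1 to compound 4 (0.18 log units; within the scatter)). At this position, then, the change from one chlorine to two fluorines leaves the number within the scatter, and the series keeps its activity in this assay range with either aryl group. No measurement at hand offers a reason for this outcome.

From the compounds shown here alone, it remains open whether any group on this ring can move the number beyond the scatter, for example a methoxy group, a dimethylamino group or a carboxylic acid in place of the halogens. Going by these compounds, it is also open whether the same swap would read alike with the other amines on the core, as in compound 2 and compound 3.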